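Piperazine nitrogen substituent exchange in a tryptamine triazole series

A few compounds are considered here, and "the series" means these few. Any claim that something is new, unique, unknown or untested is made for them only; others in the source may bear on it.

Measured so far:
compound 1 `c1coc(CN2CCN(CCCc3c[nH]c4ccc(-n5cnnc5)cc34)CC2)c1` — 18 nM
compound 2 `CN(C)C(=O)C(c1ccccc1)N1CCN(CCCc2c[nH]c3ccc(-n4cnnc4)cc23)CC1` — 102 nM

In an assay on CHO cells for displacement of a labelled ligand from 5-hydroxytryptamine receptor 1B (Homo sapiens) (a higher number here means a weaker inhibitor, a lower number a stronger inhibitor), compound 1 gives 18 nM, the lower of the two numbers; compound 2 gives 102 nM, a gap beyond the usual scatter. Compound 3 `c1ccc(N2CCN(CCCc3c[nH]c4ccc(-n5cnnc5)cc34)CC2)cc1` has not been measured. It differs from compound 1 in phenyl in place of (furan-2-yl)methyl on an amine nitrogen in a ring. Among the measured compounds shown here, no step between measured compounds covers this exchange, so the expected step is taken as a 1.2-fold lower number from compound 1 to compound 3 (0.08 log units; within the scatter), within the scatter or a small gain. Compound 3 is therefore expected near 15 nM in this assay, with a range from 4 nM to 60 nM.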

Compound 3, half-maximal inhibitory concentration: 13 nM
Compound 3: middle estimate off by 1.2-fold (0.06 log units), on the high side; low and high end bracket the measured number.
By their numbers in this assay, from the lowest: compounds 3 and 1 (each within the scatter of the next); then compound 2.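

In this assay, phenyl in place of (furan-2-yl)methyl on an amine nitrogen in a ring gives a 1.4-fold lower number from compound 1 to compound 3 (0.14 log units; within the scatter). At this position, the oxygen-bearing five-membered aromatic ring and its hydrogen-bond acceptor can therefore be exchanged for a carbon-only six-membered aromatic ring without a change beyond the scatter. No supporting evidence bears on this result.

Open, going by these compounds, is whether benzyl, which would separate the phenyl ring from this nitrogen as in (furan-2-yl)methyl, would hold the number. Also open, on these data alone, is how a pyridine ring or a fluorine-substituted phenyl would read here.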